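The compounds below may be only part of what the source reports. "The series", "measured", "known", "first", "only" and "open" are said of these compounds alone.

Of the compounds shown here, two have been measured so far in a functional assay on MCF7 cells (Homo sapiens) for antiproliferative activity, read by MTT assay, with a stated time of 72 h; a lower number here means a stronger inhibitor, a higher number a weaker inhibitor. Compound 1 `COc1ccc(/C=C/C(=O)c2ccc(N3CCNCC3)cc2)c(OC)c1` gives 16400 nM, and compound 2 `CCN1CCC(c2cc(C(=O)/C=C/c3ccccc3)c(OC)cc2OC)CC1` gives 4800 nM. Compound 2 therefore has the lower of the two numbers, and the gap between them lies beyond the usual scatter of repeated measurements. The two compounds differ in more than one place, so this gap cannot be tied to any single group.

Compound 3 `CCN1CCC(c2cc(C(=O)/C=C/c3ccccc3Cl)c(OC)cc2OC)CC1` differs from compound 2 in one place, with chloro in place of hydrogen on an aromatic carbon. This turns the 2-phenylethenyl group into a 2-(2-chlorophenyl)ethenyl group, with the chloro ortho to a large group. Going by the values given here, no measured pair shows what this exchange does in this assay, so any forecast is loose. A small step towards a somewhat lower number is expected, and it may well stay within the scatter. The expected change is a 1.4-fold lower number from compound 2 to compound 3 (0.14 log units; within the scatter). For compound 3 the estimated value is 3500 nM, with an expected range from 1500 nM to 9000 nM.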

Compound 3, half-maximal inhibitory concentration: 2600 nM
Compound 3: the middle estimate sits 1.3-fold (0.13 log units) above what was measured; measured number inside the range.
By their numbers in this assay, from the lowest: compounds 3 and 2 (each within the scatter of the next); then compound 1.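

In this assay, going by these compounds alone, this is the first pair in which one exchange can be read alone: chloro in place of hydrogen on an aromatic carbon, ortho to a large group, gives a 1.8-fold lower number from compound 2 to compound 3 (0.27 log units; within the scatter) and so turns phenyl into 2-chlorophenyl. Since that step lies within the usual scatter of repeated measurements, compound 2 and compound 3 cannot be told apart, which means that this carbon can carry a chlorine atom without a clear loss of activity, while no real gain can be claimed from this single pair either. Nothing in the available data gives a measured reason for how this exchange acts on the antiproliferative read-out.

The compounds shown leave open whether a clear step could be reached at this same carbon with another group, such as fluoro, a nitrile, a hydroxyl or an amine, any of which would test the position further than one chloro can. They also leave open whether chloro gives a similar result at other carbons of the same phenyl ring, and whether one such pair would hold up when repeated on a different shared core.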